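Replacing a Large Amine with Azetidine on the Core

This account rests on a few compounds, and the source may have more. Where it says the series, first, only, none or still open, it means among the compounds named here.

Measured compounds in a functional assay on SV5A8 cells (Homo sapiens) for cytotoxicity; on this read-out lower numbers stand for stronger inhibition and higher numbers for weaker inhibition:
- Compound 1, `Cc1ccc2c(NCc3ccc(NC(=O)C4CCN(Cc5ccccc5)CC4)cc3)nc(N3CCC(N4CCCC4)CC3)nc2c1`, gives > 8090 nM, which is a limit of this assay.
- Compound 2, `Cc1ccc2c(NCc3ccc(NC(=O)C4CCN(Cc5ncc[nH]5)CC4)cc3)nc(N(C)C)nc2c1`, gives > 20000 nM, also a limit.
- Compound 3, `Cc1ccc2c(NCc3ccc(NC(=O)C4CCN(C)CC4)cc3)nc(N(C)C)nc2c1`, gives > 17300 nM, again a limit.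

Compound 1 therefore stands only at a limit in this assay, marked by the limit of > 8090 nM in this assay, at which 1 of the 3 values shown sits; no number is known for it, and the same holds for the other two compounds, at the limit of > 20000 nM in this assay, at which 1 of the 3 values shown sits, and (the limit of > 17300 nM in this assay, at which 1 of the 3 values shown sits).

Compound 4, `Cc1ccc2c(NCc3ccc(NC(=O)C4CCN(Cc5ccccc5)CC4)cc3)nc(N3CCC3)nc2c1`, has not yet been measured. It differs from compound 1 in one place: azetidin-1-yl in place of 4-(pyrrolidin-1-yl)piperidin-1-yl on an aromatic carbon.

Among the measured compounds shown here, only one measured step exists, a step that the two limits leave unreadable from compound 2 to compound 3, and it lies at a different part of the molecule. Both of its ends are limits, so its size cannot be read. For the measured compounds named here, no measured step bears on the change from compound 1 to compound 4, and none gives a direction.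

With nothing to indicate a change, compound 4 is expected to remain near the limit of this assay, estimated at 15000 nM within 5000 nM to 40000 nM. This estimate means a step that the limit leaves unreadable from compound 1 to compound 4, expected to be no more than the scatter.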

Compound 4, half-maximal inhibitory concentration: > 8500 nM
Compound 4 was reported as a limit (the forecaster's own chance of this, stated with the estimate: 75%); the middle value is on the limit's open side.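

Among the compounds shown here, compound 1 and compound 4 are both reported only as limits in this assay, so no step between them can be read. The compounds shown leave open how strongly any of them inhibits, and whether azetidin-1-yl in place of 4-(pyrrolidin-1-yl)piperidin-1-yl changes that at all.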